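From methoxy to cyano on an aromatic carbon

A few compounds are considered here, and "the series" means these few. Any claim that something is new, unique, unknown or untested is made for them only; others in the source may bear on it.

Among the compounds with values here, in a functional assay on MDA-MB-231 cells (Homo sapiens) for antiproliferative activity, read by MTT assay, with a stated time of 48 h (a higher number here means a weaker inhibitor, a lower number a stronger inhibitor), compound 2 `C=CS(=O)(=O)N1CCN(c2ncnc3sc(-c4ccc(OC)cc4)cc23)CC1` gives 29900 nM, the higher of the two numbers so far, while compound 1 `C=CS(=O)(=O)N1CCN(c2ncnc3sc(-c4ccc(C(F)(F)F)cc4)cc23)CC1` gives 6410 nM. Compound 3 `C=CS(=O)(=O)N1CCN(c2ncnc3sc(-c4ccc(C#N)cc4)cc23)CC1` carries cyano in place of methoxy on an aromatic carbon. Within the data shown here, one measured step bears on this change: a 4.7-fold higher number from compound 1 to compound 2 (0.67 log units; beyond the scatter), where methoxy took the place of trifluoromethyl. Compound 3 has no methoxy either, so a somewhat smaller step toward a lower number is expected in this assay. The estimated step is a 2.7-fold lower number from compound 2 to compound 3 (0.43 log units; beyond the scatter). For compound 3 the expected value is 11000 nM, with an estimated range of 4500 nM to 28000 nM.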

Compound 3, half-maximal inhibitory concentration: 8050 nM
Compound 3: middle estimate off by 1.4-fold (0.14 log units), on the high side; the measured number falls inside the stated range.
By their numbers in this assay, from the lowest: compounds 1 and 3 (each within the scatter of the next); then compound 2.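

In this assay, putting cyano in place of methoxy on the aromatic ring gives a 3.7-fold lower number from compound 2 to compound 3 (0.57 log units; beyond the scatter), so methoxy now stands apart from two other groups rather than one. Cyano in place of trifluoromethyl gives a 1.3-fold higher number from compound 1 to compound 3 (0.10 log units; within the scatter), so this assay does not separate these two groups at this position. No measurement shown here offers an explanation for these numbers. The compounds shown leave open how a plain hydrogen, a chlorine atom or an amine would compare at this position.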